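Methyl for chloro on the aryl ring: lipophilicity notes

This account rests on a few compounds, and the source may have more. Where it says the series, first, only, none or still open, it means among the compounds named here.

Measured compounds:
- compound 1, `Cc1cccc(C2=NC(c3ccccc3)CO2)c1`, 4.11 in a physicochemical assay for lipophilicity; a lower number here means a more polar compound, a higher number a more lipophilic compound
- compound 2, `Clc1cccc(C2=NC(c3ccccc3)CO2)c1`, 4.44 in this assay
- compound 3, `Clc1ccccc1C1=NC(c2ccccc2)CO1`, 3.56 in this assay

Compound 2 and compound 3 are built from the same atoms joined differently; the difference between the two cores is not broken down here. Among the three, compound 3 gives the lowest value in this assay.

One change has been measured once: methyl in place of chloro on an aromatic carbon, which gave a number 0.33 log units lower from compound 2 to compound 1 (beyond the scatter).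

Compound 4, `Cc1ccccc1C1=NC(c2ccccc2)CO1`, is not yet measured in this assay. It stands to compound 3 as compound 1 stands to compound 2: methyl in place of chloro on an aromatic carbon. The place differs in its printed words, meta to a large group in compound 1 against ortho to a large group in compound 4, so the change is the same kind of change, not the same. No second measurement of this kind of change exists.

For compound 4 the expected step is a number 0.31 log units lower from compound 3 to compound 4 (beyond the scatter), resting on compound 2 to compound 1 giving a number 0.33 log units lower from compound 2 to compound 1 (beyond the scatter) and on compound 3 giving 3.56. Compound 4 is therefore estimated at 3.25, between 2.9 and 3.6.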

Compound 4, partition coefficient: 3.68
The estimate for compound 4 lay 0.43 log units below the measured number; measured number outside the range, above it.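

In this assay, methyl in place of chloro on an aromatic carbon gave a number 0.33 log units lower from compound 2 to compound 1 (beyond the scatter), whereas the same kind of change, ortho to a large group on the other core, gave a number 0.12 log units higher from compound 3 to compound 4 (within the scatter). The step therefore did not carry from one core to the other in this pair of cases: a step beyond the scatter on one core stands beside a step within the scatter on the other. Core and place vary together across just these two pairs, so neither can be singled out, the result gives no general rule for the series, and no measurement at hand bears on the reason for the difference.

The compounds shown leave open how an amine or a carboxylic acid in place of chloro would read in this assay on either core. They also leave open whether an ethyl group or a longer chain would follow the methyl steps, and which of the two steps a further matched pair would resemble.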